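Methyl in place of fluoro: compound 3 to compound 4

The source may report more compounds than this note shows. Statements on the series, on what has been measured and on what is new or still open speak of the compounds shown alone.

The series keeps the core of compound 1 `COc1ccc(C(=O)N(CCN2CCC(OCC(=O)O)CC2)c2ccc(C)cc2)cc1` and varies the group on the carbonyl carbon. In a functional assay on a cell-free system (Platelet, plasma, Homo sapiens) for inhibition (a higher number here means a weaker inhibitor, a lower number a stronger inhibitor), compound 1 gives 1200 nM. Compound 2 `Cc1ccc(N(CCN2CCC(OCC(=O)O)CC2)C(=O)c2ccc(C(F)(F)F)cc2)cc1` reads > 10000 nM, which is a limit of the assay and not a number. For the measured compounds named here, compound 3 `Cc1ccc(N(CCN2CCC(OCC(=O)O)CC2)C(=O)c2cccc(F)c2)cc1` gives 160 nM, the lower of the two actual numbers so far.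

Compound 4 `Cc1ccc(N(CCN2CCC(OCC(=O)O)CC2)C(=O)c2cccc(C)c2)cc1` carries 3-methylphenyl in place of 3-fluorophenyl: methyl in place of fluoro on an aromatic carbon. The change is methyl in place of fluoro on an aromatic carbon, meta to a large group.

Going by the values given here, no measured step makes this swap directly. The nearest evidence is 3-fluorophenyl in place of 4-methoxyphenyl, giving a 7.5-fold lower number from compound 1 to compound 3 (0.88 log units; beyond the scatter), and 3-fluorophenyl in place of 4-(trifluoromethyl)phenyl, giving an at least 62-fold lower number from compound 2 to compound 3 (1.79 log units; beyond the scatter). Trifluoromethyl in place of methoxy gave an at least 8.3-fold higher number from compound 1 to compound 2 (0.92 log units; beyond the scatter), so changes to this group have moved the number widely, but each of these steps starts from a 4-substituted phenyl. Compound 4 stays 3-substituted like compound 3 at 160 nM, so only a small move towards a higher number is expected in this assay, probably not beyond the scatter. The estimated change is a 1.8-fold higher number from compound 3 to compound 4 (0.24 log units; within the scatter). Compound 4 is expected at about 280 nM, with an estimated range from 90 nM to 1000 nM.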

Compound 4, half-maximal inhibitory concentration: 160 nM
Compound 4: middle estimate off by 1.8-fold (0.24 log units), on the high side; the range from low to high includes it.
By their numbers in this assay, from the lowest: compounds 3 and 4 (each within the scatter of the next); then compound 1. At a limit, above all of these: compound 2.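

In this assay, for the compounds shown here, methyl in place of fluoro on an aromatic carbon, meta to a large group, gives no change at the digits printed from compound 3 to compound 4 (within the scatter), so this assay does not separate the two groups at this place, a direct reading that the earlier steps between differently placed groups could not give. The gain over the 4-methoxyphenyl compound is therefore not confined to 3-fluorophenyl: 3-methylphenyl gives a 7.5-fold lower number from compound 1 to compound 4 (0.88 log units; beyond the scatter), matching a 7.5-fold lower number from compound 1 to compound 3 (0.88 log units; beyond the scatter). The same holds against the 4-(trifluoromethyl)phenyl compound, with an at least 62-fold lower number from compound 2 to compound 4 (1.79 log units; beyond the scatter), although that step starts from a limit and not a number: the limit of > 10000 nM in this assay, at which 1 of the 4 values shown sits.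

Still open, from the compounds shown here alone, is how much of these gaps belongs to the place of the substituent and how much to the group itself, as compound 1 and compound 2 differ from compound 3 and compound 4 in both; 3-methoxyphenyl or 3-(trifluoromethyl)phenyl on the carbonyl carbon would separate the two. Also open, going by these compounds, is whether the flat reading extends to groups of another kind at this place, such as an amine or a nitrile.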